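Swapping Dichlorophenyl for Dimethylphenyl on a Second Core

A few compounds are considered here, and "the series" means these few. Any claim that something is new, unique, unknown or untested is made for them only; others in the source may bear on it.

Compound 1 `Cc1cccc(N2CCN(CCCNc3nc(NCc4ccco4)c4ccccc4n3)CC2)c1C` gives 3310 nM in a functional assay on MCF7 cells (Homo sapiens) for cytotoxicity, read by MTT assay, with a stated time of 2 days; a higher number here means a weaker inhibitor, a lower number a stronger inhibitor.
Compound 3 `Clc1cccc(N2CCN(CCCNc3nc(NCc4ccco4)c4ccccc4n3)CC2)c1Cl` gives 2980 nM.
Compound 2 `Fc1ccc2nc(NCCCCN3CCN(c4cccc(Cl)c4Cl)CC3)nc(NCc3ccco3)c2c1` gives "not determined" (no result reported) in this assay, so no number is available for it.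

Compounds 1 and 3 share a core and differ in one place: 2,3-dimethylphenyl in place of 2,3-dichlorophenyl on an amine nitrogen in a ring. That change gave a 1.1-fold higher number from compound 3 to compound 1 (0.05 log units; within the scatter), a step inside the usual scatter. Compound 2 is built on a different core; the difference between the two cores is not broken down here, and for compound 2 no number is available. Compound 4 `Cc1cccc(N2CCN(CCCCNc3nc(NCc4ccco4)c4cc(F)ccc4n3)CC2)c1C` stands to compound 2 as compound 1 stands to compound 3: 2,3-dimethylphenyl in place of 2,3-dichlorophenyl on an amine nitrogen in a ring. The place where the group sits is described in the same words for both pairs, so this is the same change, now made on the second core. With nothing known for compound 2, the expectation rests on the first pair only: in this assay a step of similarly small size, within the scatter, is expected from compound 2 to compound 4. Compound 4 is therefore expected to land in the same region as the first pair because compound 1 gives 3310 nM. The estimate for compound 4 is 3500 nM, between 1500 nM and 9000 nM.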

Compound 4, half-maximal inhibitory concentration: 3130 nM
Compound 4: middle estimate off by 1.1-fold (0.05 log units), on the high side; the measured number falls inside the stated range.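

Compound 2 has no number in this assay, so the step from compound 2 to compound 4 cannot be read. The compounds shown leave open whether 2,3-dimethylphenyl in place of 2,3-dichlorophenyl changes the number on the core of compound 4 as little as it does on the core of compound 1. Nothing shown offers an explanation for these values.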